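Thiophene in Place of Furan on a Fused Lactone Core

A few compounds are considered here, and "the series" means these few. Any claim that something is new, unique, unknown or untested is made for them only; others in the source may bear on it.

Compound 1 `CC1(C)CC(=O)C2=C(C1)OC(=O)C(NC(=O)c1ccccc1)C2c1cccs1` and compound 2 `O=C1CCCC2=C1C(c1ccco1)C(NC(=O)c1ccccc1)C(=O)O2` share a fused core. In a functional assay on SW 1116 cells (Homo sapiens) for cytotoxicity, read by MTT assay, with a stated time of 24 h, tested at 10 ug/mL (on this read-out lower numbers stand for a stronger effect and higher numbers for a weaker effect at the one concentration tested), compound 1 gives 50.5%, while compound 2 gives 74.2%, the higher of the two numbers and separated from compound 1 by a gap beyond the scatter. Compound 3 `O=C1CCCC2=C1C(c1cccs1)C(NC(=O)c1ccccc1)C(=O)O2` differs from compound 2 in one place: thiophen-2-yl in place of furan-2-yl on a saturated ring carbon. For the measured compounds named here, no step between measured compounds is known. Compound 1, which carries the thiophen-2-yl group, gives 50.5% in this assay. On that basis a modest downward step is expected, a number 14.2 percentage points lower from compound 2 to compound 3 (beyond the scatter). Compound 3 is expected to show 60% in this assay, within 45% to 78%.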

Compound 3, a percentage reported as activity, at one concentration (the size of the read-out at that concentration, not a potency): 69.7%
Beside the measured number, compound 3's estimate is 9.7 percentage points below it, and the stated range covers the measured number.
By their numbers in this assay, from the lowest: compound 1; then compounds 3 and 2 (each within the scatter of the next).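

Thiophen-2-yl in place of furan-2-yl on a saturated ring carbon gives a number 4.5 percentage points lower from compound 2 to compound 3 (within the scatter) in this assay and is the first change here made in one place alone. On the shared core, the two groups therefore cannot be told apart in this read-out. Nothing at hand accounts for this result.

From the compounds shown here alone, whether a phenyl ring or an aminomethyl group on this saturated ring carbon would give a step beyond the scatter remains open. So does whether the same exchange would give a similar step on the core of compound 1.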